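Amide substituents on a nitrobenzoxadiazole glutathione S-transferase inhibitor scaffold

A few compounds are considered here, and "the series" means these few. Any claim that something is new, unique, unknown or untested is made for them only; others in the source may bear on it.

Measured compounds:
compound 1, `O=C(O)CCC(=O)OCCCCCCSc1ccc([N+](=O)[O-])c2nonc12`, 530 nM
compound 2, `Cc1ccccc1NC(=O)CCC(=O)OCCCCCCSc1ccc([N+](=O)[O-])c2nonc12`, 4100 nM
compound 3, `Cc1ccc(NC(=O)CCC(=O)OCCCCCCSc2ccc([N+](=O)[O-])c3nonc23)cc1`, 6800 nM

In an assay on isolated protein for inhibition of glutathione S-transferase P (Homo sapiens), with a stated time of 10 min (on this read-out higher numbers stand for weaker inhibition and lower numbers for stronger inhibition), compound 1 gives the lowest number of the three. Replacing the hydroxy on the carbonyl carbon by an arylamino raises the number: a 7.7-fold higher number from compound 1 to compound 2 (0.89 log units; beyond the scatter) and a 13-fold higher number from compound 1 to compound 3 (1.11 log units; beyond the scatter). The two aryl amides lie close together, a 1.7-fold higher number from compound 2 to compound 3 (0.22 log units; within the scatter), so compound 3 stands at the highest number of the three, yet is not separated from compound 2 beyond the scatter.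

Compound 4, `CCN(CC)CCCNC(=O)CCC(=O)OCCCCCCSc1ccc([N+](=O)[O-])c2nonc12`, differs from compound 3 by 3-(diethylamino)propyl in place of 4-methylphenyl on an amide-type nitrogen. Going by the values given here, no measured step changes the substituent on the amide nitrogen in this way; the only step on that nitrogen, from compound 2 to compound 3, stays within the scatter. The two steps from compound 1 show that both arylamino groups weaken inhibition relative to the free acid, but they give no guide to an aminoalkyl amide. The author therefore expects compound 4 to land near compound 3, with a step of a 1.4-fold lower number from compound 3 to compound 4 (0.13 log units; within the scatter). The estimate for compound 4 in this assay is 5000 nM, with a range from 1500 nM to 15000 nM.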

Compound 4, half-maximal inhibitory concentration: 9550 nM
For compound 4 the middle estimate is 1.9-fold (0.28 log units) below the measured one; measured number inside the range.
By their numbers in this assay, from the lowest: compound 1; then compounds 2, 3 and 4 (each within the scatter of the next, the first and the last beyond it).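

On the amide-type nitrogen in this assay, exchanging the 4-methylphenyl, with its six-membered aromatic ring of carbon only, for 3-(diethylamino)propyl, which has no ring and carries one hydrogen-bond acceptor, gives a 1.4-fold higher number from compound 3 to compound 4 (0.15 log units; within the scatter), so in this pair the aromatic ring and the open chain cannot be told apart. The comparison with the other aryl amide reads differently, with a 2.3-fold higher number from compound 2 to compound 4 (0.37 log units; beyond the scatter), and the step from the free acid is the largest in this set, at an 18-fold higher number from compound 1 to compound 4 (1.26 log units; beyond the scatter), so all three amides stand well away from compound 1 whether the group on the nitrogen is aromatic or not. Nothing available here explains these numbers.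

The compounds shown leave open whether the distance from compound 1 belongs to the amide link itself or to what it carries, which a plain primary amide or a methyl amide on the same carbonyl carbon would help to separate. Also open, going by these compounds, is whether a propyl chain ending in a carboxylic acid instead of the diethylamine, or a longer chain before that amine, would move the number at all.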